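Swapping methylsulfanyl for a selenium-bearing group

The source may hold more compounds than are shown below. What is called first, only, known or untested is meant among the compounds shown, and "the series" means these compounds.

Compound 1 `CS/C(=N\C(=O)c1csc([N+](=O)[O-])c1)NC(=O)c1csc([N+](=O)[O-])c1` was tested in a functional assay on MCF7 cells (Homo sapiens) for cytotoxicity, read by MTT assay, with a stated time of 72 h (on this read-out higher numbers stand for weaker inhibition of growth and lower numbers for stronger inhibition of growth), where compound 1 gives 78100 nM. Among the two compounds with a number, compound 1 stands at the higher one; compound 2 `CS/C(=N\C(=O)c1cc2ccccc2s1)NC(=O)c1cc2ccccc2s1` gives 43400 nM in this assay, and the two values lie within the usual scatter of each other, so no order can be drawn between them. Compound 3 `O=C(/N=C(/NC(=O)c1cccs1)[Se]Cc1ccccc1)c1cccs1` reaches only a limit of this assay, > 100000 nM. Compound 4 `O=C(/N=C(/NC(=O)c1csc([N+](=O)[O-])c1)[Se]Cc1ccccc1)c1csc([N+](=O)[O-])c1` has not yet been measured; it differs from compound 1 in one place: a group of 8 heavy atoms (7 carbon, 1 selenium; one six-membered aromatic ring of carbon only) in place of a group of 2 heavy atoms (1 carbon, 1 sulfur; no ring), on a carbon with a double bond to nitrogen, on a carbon with a double bond to nitrogen. Among the compounds with values here, no measured pair shows this change on the core of compound 1, so its size is unknown. Compound 4 is expected to give 120000 nM in this assay, within 50000 nM to 300000 nM, because compound 3 carries the same entering group and sits at the limit (the limit of > 100000 nM in this assay, at which 1 of the 3 values shown sits). The estimated step of a 1.5-fold higher number from compound 1 to compound 4 (0.19 log units; within the scatter) is toward weaker inhibition, and a limit rather than a number is also plausible.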

Compound 4, concentration for total growth inhibition: 54100 nM
Compound 4: middle estimate off by 2.2-fold (0.35 log units), on the high side, and the stated range covers the measured number.
By their numbers in this assay, from the lowest: compounds 2, 4 and 1 (each within the scatter of the next). At a limit, above all of these: compound 3.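

On the core of compound 1, putting the selenium-bearing group with its six-membered aromatic ring in place of methylsulfanyl, on the carbon with a double bond to nitrogen, amounts to a 1.4-fold lower number from compound 1 to compound 4 (0.16 log units; within the scatter) in this assay. This carbon therefore carries a much larger group with no difference that can be told from the scatter, so the swap alone neither strengthens nor weakens growth inhibition measurably on this core. Compound 3 is the only compound at a limit, which is not a number: the limit of > 100000 nM in this assay, at which 1 of the 4 values shown sits.

The compounds shown leave open whether any group on this carbon can move the number beyond the scatter, for instance an amine or a longer alkyl chain in place of methylsulfanyl. Also open, from the compounds shown here alone, is whether the same swap reads the same way on the core of compound 2.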